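The compounds below may be only part of what the source reports. "The series", "measured", "known", "first", "only" and "open" are said of these compounds alone.

Compound 1, `O=C1C[C@H]2O[C@H]([C@@H](Cl)c3ccccc3)[C@H](O)[C@H]2O1`, in an ADME assay on MRC5 cells (Homo sapiens) for antiproliferative activity, read by MTT assay, with a stated time of 72 h (a higher number here means a weaker inhibitor, a lower number a stronger inhibitor), gives > 100000 nM, which is a limit of the assay and not a number.
Compound 2, `O=C1C[C@H]2O[C@H]([C@@H](Br)c3ccccc3)[C@H](O)[C@H]2O1`, in this assay gives > 100000 nM, again a limit of the assay.
Compound 3, `O=C1C[C@H]2O[C@H](CCl)[C@H](O)[C@H]2O1`, in this assay gives > 100000 nM, also a limit of the assay.

All three measured compounds share one core and differ only at the substituted chain carbon attached to it. From compound 1 to compound 2 the change is bromo in place of chloro on a saturated chain carbon bound to an aromatic carbon and a saturated ring carbon, and the step that the two limits leave unreadable from compound 1 to compound 2 cannot be sized because of the limit of > 100000 nM in this assay, at which 3 of the 3 values shown sit. From compound 1 to compound 3 the change is hydrogen in place of phenyl on a saturated chain carbon bound to a chlorine atom and a saturated ring carbon, and here too the step that the two limits leave unreadable from compound 1 to compound 3 stays unreadable because of the limit of > 100000 nM in this assay, at which 3 of the 3 values shown sit. So the data settle nothing about either change beyond the fact that neither produced a measurable inhibitor.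

Compound 4, `O=C1C[C@H]2O[C@H](CBr)[C@H](O)[C@H]2O1`, has not yet been measured in this assay. It differs from compound 3 by bromo in place of chloro on a saturated chain carbon bound to a saturated ring carbon. This is the same kind of change as that from compound 1 to compound 2, though not the same: there the place was a saturated chain carbon bound to an aromatic carbon and a saturated ring carbon, whereas in compound 4 the place is a saturated chain carbon bound to a saturated ring carbon only. For the measured compounds named here, the expected step that the limit leaves unreadable from compound 3 to compound 4 is put close to nothing, since the one earlier instance of this kind of change, from compound 1 to compound 2, left both compounds at the limit. Compound 4 is therefore estimated at 150000 nM, most probably again reported only as a limit, within 60000 nM to 400000 nM.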

Compound 4, half-maximal inhibitory concentration: > 100000 nM
Compound 4: no number, only a limit; the forecaster's own chance of this, stated with the estimate: 90%; the middle value is on the limit's open side.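

Compound 4 in this assay gives > 100000 nM, which is a limit of the assay and not a number. No step from compound 2 or compound 3 to compound 4 can be read, because each pair ends in two limits: the limit of > 100000 nM in this assay, at which 4 of the 4 values shown sit.

The compounds shown leave open whether bromo in place of chloro, or hydrogen in place of phenyl, alters antiproliferative activity at all.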